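This account rests on a few compounds, and the source may have more. Where it says the series, first, only, none or still open, it means among the compounds named here.

Measured compounds:
compound 1 `COc1cccc(N2CCN(C(=O)c3oc(C(F)(F)F)nc3-c3cccc(F)c3)CC2)c1` — "not active" (no number reported)
compound 2 `Cc1nc(-c2ccccc2)c(C(=O)N2CCN(c3cccc(C(N)=O)c3)CC2)o1` — 71 nM

Among the compounds with values here, in a functional assay on HL-60 cells (Homo sapiens) for inhibition, read by MTT assay, with a stated time of 72 h (a higher number here means a weaker inhibitor, a lower number a stronger inhibitor), compound 2 gives 71 nM, the only number in this set. Compound 1 is recorded in this assay as "not active" (no number reported), with no number behind that word. Within the data shown here, compound 1 differs from compound 2 at several places, so no single step can be traced between them.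

Compound 3 `Cc1nc(-c2ccccc2)c(C(=O)N2CCN(c3ccccc3)CC2)o1` is not yet measured. It differs from compound 2 by hydrogen in place of carbamoyl on an aromatic carbon of a six-membered aromatic ring of carbon only. Among the measured compounds shown here, no step between measured compounds in this assay isolates this change. For the measured compounds named here, since compound 2 holds the only number, and compound 1, which also lacks the carbamoyl, is "not active" (no number reported), a loss of potency beyond the scatter is expected. Compound 3 is estimated at 350 nM, in the range 80 nM to 1500 nM. This corresponds to an expected step of a 4.9-fold higher number from compound 2 to compound 3 (0.69 log units; beyond the scatter).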

Compound 3, half-maximal inhibitory concentration: 39.1 nM
Compound 3: the middle estimate sits 9.0-fold (0.95 log units) above what was measured; the whole stated range lies above it.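

In this assay, within the data shown here, putting hydrogen in place of carbamoyl on the aromatic carbon gives a 1.8-fold lower number from compound 2 to compound 3 (0.26 log units; within the scatter) as the first step that can be traced at this position. It shows that 3-carbamoylphenyl and phenyl cannot be told apart here, so the carbamoyl group is not required for a number in this range. No measurement at hand offers an explanation for this result.

From the compounds shown here alone, whether this aromatic carbon accepts other groups stays open, for instance an amine or a carboxylic acid in the same place. Going by these compounds, it also stays open which of its several differences from the other compounds goes with compound 1 being recorded as "not active" (no number reported) in this assay, and the trifluoromethyl group and the fluorine it carries are not separated from one another.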